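Trifluoromethyl Removal and Cytotoxicity in Two Related Pairs

The source may report more compounds than this note shows. Statements on the series, on what has been measured and on what is new or still open speak of the compounds shown alone.

Compound 1 `FC(F)(F)c1cccc(/N=N/N2CCCC2)c1` and compound 2 `CN(C)CCCN(/N=N/c1ccccc1)c1cccc(C(F)(F)F)c1` were tested in an ADME assay on MT4 cells (Homo sapiens) for cytotoxicity, read by MTT assay, with a stated time of 96 h; a higher number here means that more compound is tolerated, a lower number that less compound is tolerated. For compound 1 the result is a limit of the assay, > 100000 nM. Among the compounds with values here, compound 2 gives 14000 nM, the only number among the three measurements. Compound 3 `c1ccc(/N=N/N2CCCC2)cc1` differs from compound 1 by hydrogen in place of trifluoromethyl on an aromatic carbon; for compound 3 the result is again a limit, > 100000 nM. The step is therefore unreadable: a step that the two limits leave unreadable from compound 1 to compound 3. The difference between the cores of compound 1 and compound 2 is not broken down here. Compound 4 `CN(C)CCCN(/N=N/c1ccccc1)c1ccccc1` carries the same kind of change from compound 2, (hydrogen in place of trifluoromethyl on an aromatic carbon), the group sitting "meta to a large group" rather than "meta to a group of 7 heavy atoms". Since the limit of > 100000 nM in this assay, at which 2 of the 3 values shown sit, covers both compound 1 and compound 3, no measured step sizes this change. In this assay a modest step is expected, a 1.8-fold higher number from compound 2 to compound 4 (0.25 log units; within the scatter), resting on compound 2 at 14000 nM. For compound 4 the estimate is 25000 nM, between 8000 nM and 100000 nM.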

Compound 4, half-maximal cytotoxic concentration: 33000 nM
Estimate against measurement, compound 4: 1.3-fold (0.12 log units) below; measured number inside the range.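

In this assay hydrogen in place of trifluoromethyl on an aromatic carbon gives a 2.4-fold higher number from compound 2 to compound 4 (0.37 log units; beyond the scatter) on that one core. The same change on the core of compound 1 cannot be read, because compound 1 and compound 3 both stand at a limit rather than a number: the limit of > 100000 nM in this assay, at which 2 of the 4 values shown sit. The series thus sizes this change on a single core and does not show whether that size carries over to another core.

On these data alone, what a nitrile or a carboxylic acid in place of trifluoromethyl would give on either core remains open. So does whether any compound on the core of compound 1 would give a number rather than a limit.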